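This account rests on a few compounds, and the source may have more. Where it says the series, first, only, none or still open, it means among the compounds named here.

Compound 1 `O=C(Nc1ccccc1C(F)(F)F)C1CCc2ccccc2N1C(=O)c1ccccc1`: 5290 nM
Compound 2 `O=C(Nc1ccccc1O)C1CCc2ccccc2N1C(=O)c1ccccc1`: 4210 nM
Compound 3 `O=C(Nc1ccccc1C(F)(F)F)C1CCc2ccccc2N1C(=O)c1ccc(Cl)cc1`: 533 nM

These three compounds share one core and were all measured in a functional assay on MDA-MB-231 cells (Homo sapiens) for cytotoxicity, read by sulforhodamine B assay, with a stated time of 72 h; on this read-out higher numbers stand for weaker inhibition of growth and lower numbers for stronger inhibition of growth. Compound 2 has the second highest of the three numbers: it sits within the scatter of compound 1, the step being a 1.3-fold lower number from compound 1 to compound 2 (0.10 log units; within the scatter), while compound 3 at 533 nM lies beyond the scatter from both of them.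

Compound 4 `CC(=O)N1c2ccccc2CCC1C(=O)Nc1ccccc1O` differs from compound 2 in one place: methyl in place of phenyl on a carbonyl carbon. Among the measured compounds shown here, no measured step tests this change directly. The step of a 9.9-fold lower number from compound 1 to compound 3 (1.00 log units; beyond the scatter), a modest one beyond the scatter, shows that a change made on the phenyl that leaves here can move the number, whereas the step of a 1.3-fold lower number from compound 1 to compound 2 (0.10 log units; within the scatter) on the other ring stays within the scatter. Removing that phenyl altogether is a larger change than adding chloro to it, and the direction cannot be read from the measured compounds, so the estimate leans toward a somewhat higher number with wide bounds. Compound 4 is therefore expected to give 7500 nM in this assay, with a range from 2500 nM to 22000 nM. That expectation means an estimated step of a 1.8-fold higher number from compound 2 to compound 4 (0.25 log units; within the scatter), which may still fall within the scatter.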

Compound 4, concentration for 50% growth inhibition: 89600 nM
Estimate against measurement, compound 4: 12-fold (1.08 log units) below, outside the stated range (above it).
By their numbers in this assay, from the lowest: compound 3; then compounds 2 and 1 (each within the scatter of the next); then compound 4.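

In this assay, among the compounds shown here, methyl in place of phenyl on the carbonyl carbon gives a 21-fold higher number from compound 2 to compound 4 (1.33 log units; beyond the scatter), a large step beyond the scatter, so the phenyl that leaves here matters far more to the number than the earlier compounds could show. For the compounds shown here, until now, the only evidence from this part of the molecule was a substitution on that phenyl, with chloro in place of hydrogen giving a 9.9-fold lower number from compound 1 to compound 3 (1.00 log units; beyond the scatter) in the opposite direction; the new step shows that removing the ring moves the number further than that substitution did, and towards weaker inhibition of growth. The compounds shown include no measurement that explains why benzoyl to acetyl has so large an effect, so the step stands as an observation only.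

With only phenyl, 4-chlorophenyl and methyl on this carbonyl carbon, the compounds shown leave open whether a longer chain such as propyl, a saturated ring such as cyclohexyl, or a chain ending in an amine would stay near compound 4 or return towards compound 2. They also leave open whether the same change would give a step of similar size with trifluoromethyl in place of hydroxy on the other aromatic ring.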